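Moving the Chlorine on One Aryl Ring

The source may report more compounds than this note shows. Statements on the series, on what has been measured and on what is new or still open speak of the compounds shown alone.

Measured so far:
- compound 1 `O=C(NO)c1ccc(NCc2nc(-c3ccc(Cl)cc3)nn2-c2ccccc2)cc1` gives 181 nM in an assay on Sf9 cells for inhibition of protein deacetylase HDAC6 (Homo sapiens), read by fluorescence, with a stated time of 40 min; on this read-out lower numbers stand for stronger inhibition and higher numbers for weaker inhibition
- compound 2 `O=C(NO)c1ccc(NCc2nc(-c3ccccc3)nn2-c2ccc(Br)cc2)cc1` gives 1730 nM in this assay
- compound 3 `O=C(NO)c1ccc(NCc2nc(-c3cccs3)nn2-c2ccc(O)cc2)cc1` gives 33.5 nM in this assay

All three share the same core, a hydroxamic acid linked through an aniline to a five-membered ring carrying two aryl groups. Among these three numbers compound 1 stands second highest. Compound 3 sits clearly lower and compound 2 clearly higher, and both gaps lie beyond the usual scatter, so compound 1 is neither the strongest nor the weakest of the set. Compounds 2 and 3 each differ from compound 1 in more than one place, so none of these pairs isolates a single change.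

Compound 4 `O=C(NO)c1ccc(NCc2nc(-c3ccccc3Cl)nn2-c2ccccc2)cc1` differs from compound 1 in one way: 2-chlorophenyl in place of 4-chlorophenyl on an aromatic carbon. The atoms are the same, only joined differently. For the measured compounds named here, no measured pair shows what this rearrangement does, so the expectation rests on the change itself. Such a shift of a chlorine is expected to give a modest step, likely upward in this assay, and it may well stay within the scatter. The step from compound 1 to compound 4 is estimated at a 1.7-fold higher number from compound 1 to compound 4 (0.22 log units; within the scatter). Compound 4 is therefore estimated at 300 nM, with a plausible range from 100 nM to 1000 nM.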

Compound 4, half-maximal inhibitory concentration: 185 nM
The estimate for compound 4 lay 1.6-fold (0.21 log units) above the measured number; the measured number falls inside the stated range.
By their numbers in this assay, from the lowest: compound 3; then compounds 1 and 4 (each within the scatter of the next); then compound 2.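

For the compounds shown here, this pair is the first in the set to isolate a single change. In this assay, swapping 4-chlorophenyl for 2-chlorophenyl on the five-membered ring gives a 1.0-fold higher number from compound 1 to compound 4 (0.01 log units; within the scatter), so this assay does not tell the two chlorine placements apart. This makes the position on the aryl ring look forgiving for chlorine, at least for these two placements, though a single pair shows no more than that. No measurement presented here offers an explanation for this result.

On these data alone, what the chlorine itself contributes at this place remains open, as does whether the same reading would hold with the other aryl ring changed. Also open, as far as these compounds go, is whether a different group on this aryl ring, such as an amine or a carboxylic acid, would give a step beyond the scatter.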